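Swapping the aryl ether in a piperidine series

The compounds below may be only part of what the source reports. "The series", "measured", "known", "first", "only" and "open" are said of these compounds alone.

Compound 1 `CC(=O)Nc1cccc(C2CCN(CCCC(=O)c3ccc(Cl)cc3)CC2)c1`: 70 nM in an assay on isolated protein for displacement of a labelled ligand from melanin-concentrating hormone receptor 1 (Rattus norvegicus); a higher number here means a weaker inhibitor, a lower number a stronger inhibitor
Compound 2 `CC(C)C(=O)Nc1cccc(C2CCN(CCCC(=O)c3ccc(Cl)cc3)CC2)c1`: 5 nM
Compound 3 `Cc1ccc(Oc2cccc(CN3CCC(c4cccc(NC(=O)C(C)C)c4)CC3)c2)cc1`: 31 nM

Compound 3 stands second highest of the three numbers: compound 1 gives 70 nM, a higher number, while compound 2 gives 5 nM, the lowest of the set. Within the data shown here, the only step between measured compounds, a 14-fold lower number from compound 1 to compound 2 (1.15 log units; beyond the scatter), concerns the group on the carbonyl carbon, not the aryl ether, so no measured step bears directly on the change to compound 4 `CC(C)C(=O)Nc1cccc(C2CCN(Cc3cccc(Oc4ccc(Cl)c(Cl)c4)c3)CC2)c1`, which is 3,4-dichlorophenyl in place of 4-methylphenyl on an oxygen on an aromatic ring. With nothing to lean on, only a small movement in this assay is expected, a 1.6-fold lower number from compound 3 to compound 4 (0.19 log units; within the scatter). Compound 4 is therefore estimated at 20 nM, within a range of 5 nM to 80 nM.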

Compound 4, inhibition constant: 18 nM
The estimate for compound 4 lay 1.1-fold (0.05 log units) above the measured number; low and high end bracket the measured number.
By their numbers in this assay, from the lowest: compound 2; then compounds 4 and 3 (each within the scatter of the next); then compound 1.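

On an oxygen on an aromatic ring, 3,4-dichlorophenyl in place of 4-methylphenyl gives a 1.7-fold lower number from compound 3 to compound 4 (0.24 log units; within the scatter) in this assay and so stays within the scatter. Among these compounds, the earlier step concerned only the carbonyl carbon, so this is the first reading at this place, and the two groups cannot be told apart here. No evidence on the cause of this result is available. Still open, going by these compounds, is whether an amine or a carboxylic acid in place of 3,4-dichlorophenyl on that oxygen would give a step beyond the scatter.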